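This account rests on a few compounds, and the source may have more. Where it says the series, first, only, none or still open, it means among the compounds named here.

Of the compounds shown here, three of a shared core have been measured for how strongly they damage a human oral cancer cell line. In a functional assay on HSC-2 cells (Homo sapiens) for cytotoxicity (on this read-out lower numbers stand for higher toxicity in this test and higher numbers for lower toxicity in this test), compound 1 `CC(C)=CCc1c(O)cccc1C(=O)c1cc2c(cc1O)OC(C)(C)C=C2` gives 170000 nM. Compound 3 `CC(C)=CCc1c(O)cccc1C(=O)c1c(O)cc(O)c2c1OC(C)(C)C=C2` gives 92000 nM in this assay. Compound 2 `CC(C)=CCc1cc(C(=O)c2cccc(O)c2CC=C(C)C)c(O)cc1O` gives 36000 nM in this assay, the lowest of the three numbers, and its distance to compound 3 as well as to compound 1 lies beyond the usual scatter, so compound 2 is the most toxic of the three. Compound 4 `CC(C)=CCc1c(O)cccc1C(=O)c1c(O)cc(O)c(CC=C(C)C)c1O` is not yet measured. It differs from compound 2 by hydroxy in place of hydrogen on an aromatic carbon; a hydroxy group enters where a hydrogen atom leaves, ortho to a 3-methylbut-2-en-1-yl group. Within the data shown here, no pair among the measured compounds shows what such a change does, so nothing here points one way or the other. The expected step is a 1.1-fold higher number from compound 2 to compound 4 (0.05 log units; within the scatter), small and within the scatter. Compound 4 is therefore expected to give about 40000 nM, in a range from 15000 nM to 110000 nM.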

Compound 4, half-maximal cytotoxic concentration: 52000 nM
Estimate against measurement, compound 4: 1.3-fold (0.11 log units) below; measured number inside the range.
By their numbers in this assay, from the lowest: compounds 2, 4, 3 and 1 (each within the scatter of the next, the first and the last beyond it).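

Among these compounds, this is the first pair of compounds that differ in one place, so it gives the first reading of this change in this assay. A hydroxy group entering in place of a hydrogen atom, on an aromatic carbon ortho to a 3-methylbut-2-en-1-yl group and meta to two hydroxy groups, gives a 1.4-fold higher number from compound 2 to compound 4 (0.16 log units; within the scatter), so the two compounds cannot be told apart and this swap at this position leaves no clear mark on the read-out. No separate measurement offers any explanation for this result.

This is a single pair, so it cannot show whether a methoxy group, an amine or a carboxylic acid at the same carbon would also leave the number within the scatter. It also leaves open whether a hydroxy group entering elsewhere on the shared core would behave the same way.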